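Methoxycarbonyl for tert-butyl on the aryl ring

The compounds below may be only part of what the source reports. "The series", "measured", "known", "first", "only" and "open" are said of these compounds alone.

Compound 1 `CC(C)(C)c1ccc(-c2cc(N3CCC(CNS(N)(=O)=O)CC3)ncn2)cc1` gives 19300 nM in a functional assay on M21 cells (Homo sapiens) for antiproliferative activity, read by sulforhodamine B assay, with a stated time of 48 h (a higher number here means a weaker inhibitor of growth, a lower number a stronger inhibitor of growth), and compound 2 `CC(C)(C)c1ccc(-c2cc(N3CCC(CCNS(N)(=O)=O)CC3)ncn2)cc1` gives 18400 nM. The step of a 1.0-fold lower number from compound 1 to compound 2 (0.02 log units; within the scatter) leaves the two within the scatter of each other, so compound 2 stands level with compound 1. Compound 3 `COC(=O)c1ccc(-c2cc(N3CCC(CCNS(N)(=O)=O)CC3)ncn2)cc1` differs from compound 2 by methoxycarbonyl in place of tert-butyl on an aromatic carbon. Going by the values given here, no measured step touches this position, so no size or direction can be drawn from the data. Compound 3 is therefore expected near compound 2, estimated at 25000 nM (range 7000 nM to 90000 nM), a step of a 1.4-fold higher number from compound 2 to compound 3 (0.13 log units; within the scatter) that is expected to stay uncertain.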

Compound 3, concentration for 50% growth inhibition: 19600 nM
Compound 3: the middle estimate sits 1.3-fold (0.11 log units) above what was measured; the range from low to high includes it.
By their numbers in this assay, from the lowest: compounds 2, 1 and 3 (each within the scatter of the next).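

At this aromatic carbon, para to a large group, methoxycarbonyl in place of tert-butyl gives in this assay a 1.1-fold higher number from compound 2 to compound 3 (0.03 log units; within the scatter). The position therefore tolerates this exchange of an acceptor-free group for one bearing hydrogen-bond acceptors, at the same heavy-atom count, with compound 3 level with compound 2 in this read-out. No available evidence bears on why the two stand level. Still open, as far as these compounds go, is whether a carboxylic acid, an amine or a fluorine atom at this carbon would also leave the number level.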